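A few compounds are considered here, and "the series" means these few. Any claim that something is new, unique, unknown or untested is made for them only; others in the source may bear on it.

Compound 2 `COc1ccc2c(c1)CC(c1nc3c(OC)cc(-c4cn[nH]c4)cc3c(=O)[nH]1)CO2` gives 2 nM in an assay on isolated protein for inhibition of Rho-associated protein kinase 2 (Homo sapiens), read by HTRF (on this read-out higher numbers stand for weaker inhibition and lower numbers for stronger inhibition), the lowest of the two numbers shown, while compound 1 `COc1ccc2c(c1)CC(c1nc3c(N(C)CCN(C)C)cc(-c4cn[nH]c4)cc3c(=O)[nH]1)CO2` gives 21 nM. Within the data shown here, the only measured step, an 11-fold lower number from compound 1 to compound 2 (1.02 log units; beyond the scatter), exchanged a larger amine-bearing chain for methoxy at the same position. Compound 3 `COc1ccc2c(c1)CC(c1nc3c(F)cc(-c4cn[nH]c4)cc3c(=O)[nH]1)CO2` carries a further change there: fluoro in place of methoxy on an aromatic carbon. Among the measured compounds shown here, no measured step covers a methoxy-to-fluoro swap, so the direction cannot be read from the data; both groups are small, and a step not beyond the scatter seems most likely. Compound 3 is therefore expected to give 4 nM, with a range of 1 nM to 15 nM, a step of a 2.0-fold higher number from compound 2 to compound 3 (0.30 log units; within the scatter).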

Compound 3, half-maximal inhibitory concentration: 104 nM
For compound 3 the middle estimate is 26-fold (1.41 log units) below the measured one; the whole stated range lies below it.
By their numbers in this assay, from the lowest: compound 2; then compound 1; then compound 3.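

Swapping methoxy for fluoro looks like a small edit, yet it gives a 52-fold higher number from compound 2 to compound 3 (1.72 log units; beyond the scatter) and so shows that this position tolerates some small groups far better than others. A small group is also no guarantee of a low number here: the large amine-bearing chain outperforms fluoro, with a 5.0-fold higher number from compound 1 to compound 3 (0.69 log units; beyond the scatter) as the gap. Nothing available here explains why fluoro fares so poorly.

As far as these compounds go, whether ethoxy, hydroxyl or chloro at this position would stay close to compound 2 or fall towards compound 3 remains open. So does whether a plain dimethylamino group would behave like the longer chain of compound 1.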